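The source may hold more compounds than are shown below. What is called first, only, known or untested is meant among the compounds shown, and "the series" means these compounds.

Working notes on the series in an assay for inhibition of Amine oxidase [flavin-containing] B (Rattus norvegicus); a higher number here means a weaker inhibitor, a lower number a stronger inhibitor. Of the compounds shown here, two carry numbers so far. Compound 1 `Cc1ccc(COc2ccc(-c3nn(CCC#N)c(=S)o3)cc2)cc1` gives 400 nM in this assay. Compound 2 `N#CCCN1N=C(c2ccc(OCc3ccccc3)cc2)OCC1=O` gives 18 nM in this assay. Compound 2 stands lowest of the two numbers; its nearest neighbour is compound 1, whose number lies higher by a margin beyond the usual scatter. Among the measured compounds shown here, no step between measured compounds that differ in a single place has been recorded, so the two compounds can be compared only as wholes, and nothing can be read into which part of their difference carries the gap.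

Compound 3 `Cc1ccc(COc2ccc(C3=NN(CCC#N)C(=O)CO3)cc2)cc1` has not yet been measured. It differs from compound 2 as follows: methyl in place of hydrogen on an aromatic carbon. Compound 1 also carries a methyl on its benzyl part, but on a different core, so it offers no clean reading of the methyl alone. The step from compound 2 to compound 3 is expected to be a 1.4-fold higher number from compound 2 to compound 3 (0.14 log units; within the scatter), small and within the scatter in either direction. Compound 3 is estimated at 25 nM, with a range from 8 nM to 75 nM.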

Compound 3, half-maximal inhibitory concentration: 320 nM
The estimate for compound 3 lay 13-fold (1.11 log units) below the measured number; measured number outside the range, above it.
By their numbers in this assay, from the lowest: compound 2; then compounds 3 and 1 (each within the scatter of the next).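

In this assay, the series now has its first comparison between compounds that differ in one place, and it gives an 18-fold higher number from compound 2 to compound 3 (1.25 log units; beyond the scatter) for methyl in place of hydrogen on an aromatic carbon, para to a large group. The change from benzyl to 4-methylbenzyl adds one heavy atom and no hydrogen-bond donors or acceptors, yet the step lies beyond the scatter, so on this core the number responds strongly to a small change at this position of the outer ring. No measurement shown here gives a reason for the size of this step.

From the compounds shown here alone, it remains open whether a chlorine atom, a methoxy group or a longer chain such as ethyl at the same position would give a step of similar size, or whether methyl at another place on the outer ring would do so. The compounds shown also contain no pair on the core of compound 1, so this step can be read only on the core shared by compound 2 and compound 3.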